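Swapping the aryl group on a cinnamamide series

A few compounds are considered here, and "the series" means these few. Any claim that something is new, unique, unknown or untested is made for them only; others in the source may bear on it.

Measured so far in an assay on isolated protein for displacement of a labelled ligand from melanin-concentrating hormone receptor 1 (Homo sapiens); on this read-out lower numbers stand for stronger inhibition and higher numbers for weaker inhibition:
compound 1, `CCCc1cc(N2CCCCC2)c2cc(NC(=O)/C=C/c3ccc(C(F)(F)F)cc3)ccc2n1`: > 4000 nM
compound 2, `CCCc1cc(OC)c2cc(NC(=O)/C=C/c3ccc(C(F)(F)F)cc3)ccc2n1`: 26 nM
compound 3, `CCCc1cc(N)c2cc(NC(=O)/C=C/c3ccc(Cl)cc3Cl)ccc2n1`: 6.6 nM

The value of compound 1 is a limit of this assay, not a number. Among the numbers shown, compound 3 gives 6.6 nM, the lowest, and compound 2 gives 26 nM. Among the compounds with values here, the one measured step, an at least 150-fold lower number from compound 1 to compound 2 (2.18 log units; beyond the scatter), changes the group on the aromatic carbon of the shared core and leaves the aryl end of the chain untouched.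

Compound 4, `CCCc1cc(N)c2cc(NC(=O)/C=C/c3ccc(Br)cc3)ccc2n1`, is not yet measured. It differs from compound 3 as follows: 4-bromophenyl in place of 2,4-dichlorophenyl on a double-bonded chain carbon bound to a double-bonded chain carbon. No measured step changes this part of the molecule, so the one step shown gives no direct guide to the size or direction of the change here. A step of moderate size, within or just beyond the scatter, seems most plausible.

Compound 4 is therefore estimated at 15 nM, with a range from 5 nM to 50 nM. The expected step is a 2.3-fold higher number from compound 3 to compound 4 (0.36 log units; beyond the scatter).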

Compound 4, half-maximal inhibitory concentration: 4 nM
The estimate for compound 4 lay 3.8-fold (0.57 log units) above the measured number, outside the stated range (below it).
By their numbers in this assay, from the lowest: compounds 4 and 3 (each within the scatter of the next); then compound 2. At a limit, above all of these: compound 1.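

Within the data shown here, putting 4-bromophenyl in place of 2,4-dichlorophenyl gives, in this assay, a 1.7-fold lower number from compound 3 to compound 4 (0.22 log units; within the scatter), the only measured step at the aryl end of the chain. With the rest of the molecule unchanged, this aryl group can therefore go from two chlorines to one bromine, and from 8 heavy atoms to 7, without a difference that can be told from the scatter. Nothing measured here gives a reason why these two aryl groups read alike.

Both aryl groups carry halogens, so this one step says nothing about a ring with no halogen, such as plain phenyl, or one bearing a nitrile or a carboxylic acid. It also leaves open whether a longer or shorter link than this double-bonded chain would be accepted.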